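This account rests on a few compounds, and the source may have more. Where it says the series, first, only, none or still open, it means among the compounds named here.

Compound 1 `C/C(=N\NC(=O)Nc1cccc2ccccc12)c1ccc(Cl)cc1Cl` and compound 2 `COc1ccc(OC)c(/C=N/NC(=O)Nc2cccc3ccccc23)c1` share one core and differ only in the aromatic part at its far end. In a functional assay on the whole organism (strain Swiss albino) with Mus musculus as the target, in the maximal electroshock model, with a stated time of 4 h (on this read-out lower numbers stand for an effect already at smaller amounts and higher numbers for an effect only at larger amounts of compound), compound 1 gives 300 mg/kg, and compound 2 gives 300 mg/kg, so the two stand level within the scatter. Compound 3 `C/C(=N\NC(=O)Nc1cccc2ccccc12)c1ccc(Cl)cc1` differs from compound 1 by hydrogen in place of chloro on an aromatic carbon. Among the measured compounds shown here, no pair of measured compounds shows how such a change shifts this assay, so the expectation rests on compound 1 alone. The expected step is no change at the digits printed from compound 1 to compound 3 (within the scatter), none beyond the scatter. Compound 3 is therefore estimated at 300 mg/kg, between 150 mg/kg and 600 mg/kg.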

Compound 3, minimum effective dose: 300 mg/kg
Compound 3: the middle estimate sits on the measured number at the digits printed; measured number inside the range.
By their numbers in this assay, from the lowest: compounds 1, 2 and 3 (each within the scatter of the next).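

Going from 2,4-dichlorophenyl to 4-chlorophenyl gives the first step measured at this position: in this assay there is no change at the digits printed from compound 1 to compound 3 (within the scatter) on replacing chloro with hydrogen. The chloro ortho to a large group can therefore be lost without a shift in this read-out. No measurement shown here explains this result.

Still open, going by these compounds, is whether the remaining chloro can also give way to hydrogen. Also open, on these data alone, is how an amine or a carboxylic acid at the position of the lost chloro would read in this assay as well.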